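Cytotoxicity of a Bromobenzyl Ether Analogue Foreseen

A few compounds are considered here, and "the series" means these few. Any claim that something is new, unique, unknown or untested is made for them only; others in the source may bear on it.

Measured compounds:
- compound 1 `C=CCOC1=CS(=O)(=O)OC1(CC)Cc1ccccc1`: in an ADME assay on HEL cells (Homo sapiens) for cytotoxicity, with a stated time of 3 days (on this read-out higher numbers stand for lower toxicity in this test and lower numbers for higher toxicity in this test), compound 1 gives > 200000 nM, which is a limit of the assay and not a number.
- compound 2 `CCC1(Cc2ccccc2)OS(=O)(=O)C=C1OCCCc1ccccc1`: in this assay compound 2 gives 133000 nM.

Compound 2 therefore holds the only number shown in this assay; the other value for the pair is a limit. Going by the values given here, the one measured step, an at least 1.5-fold lower number from compound 1 to compound 2 (0.17 log units; that floor lies within the scatter), involves the same place on the shared core and rests on (the limit of > 200000 nM in this assay, at which 1 of the 2 values shown sits), so its floor lies within the usual scatter and says little about direction. Compound 3 `CCC1(Cc2ccccc2)OS(=O)(=O)C=C1OCc1ccc(Br)cc1` differs from compound 2 by 4-bromophenyl in place of phenethyl on a saturated chain carbon bound to an oxygen on an unsaturated carbon, an aromatic group in place of a longer chain-linked one. Among the compounds with values here, nothing among the measured compounds speaks to a bromine on that ring. The expectation for this assay is thus a step from compound 2 to compound 3 of about a 1.1-fold higher number from compound 2 to compound 3 (0.05 log units; within the scatter), not beyond the scatter, with a fair chance that compound 3 again reaches only the limit. Compound 3 is estimated at 150000 nM, in the range from 60000 nM to 300000 nM.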

Compound 3, half-maximal cytotoxic concentration: 171000 nM
Compound 3: the middle estimate sits 1.1-fold (0.06 log units) below what was measured, within the range that was stated.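

In this assay, putting 4-bromophenyl in place of phenethyl on a saturated chain carbon bound to an oxygen on an unsaturated carbon gives a 1.3-fold higher number from compound 2 to compound 3 (0.11 log units; within the scatter). Going by these compounds alone, this is the first step at this position with a number at both ends, whereas the earlier step had only a floor, and it shows that these two groups cannot be told apart in this read-out, even though they differ in their count of heavy atoms and one carries a bromine. The other new step, an at least 1.1-fold lower number from compound 1 to compound 3 (0.06 log units; that floor lies within the scatter), is only a floor set by the limit of compound 1 and gives no direction: the limit of > 200000 nM in this assay, at which 1 of the 3 values shown sits.

The compounds shown leave open what the bromine itself contributes, since plain phenyl at this place, which would separate the bromine from the rest of the group, does not appear among them. Also open, as far as these compounds go, is whether an amine or a carboxylic acid on that ring, or a longer chain at this place, would move the number beyond the scatter.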